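Changing the aryl group on the ring nitrogen

The source may hold more compounds than are shown below. What is called first, only, known or untested is meant among the compounds shown, and "the series" means these compounds.

Compound 1 `O=C1Nc2ccc(Cl)cc2/C1=N/NC(=S)N1CCN(c2ccccc2)CC1` in a functional assay on HCT-116 cells (Homo sapiens) for inhibition, read by MTT assay, with a stated time of 72 h (on this read-out higher numbers stand for weaker inhibition and lower numbers for stronger inhibition), gives 3490 nM.
Compound 2 `COc1ccc(N2CCN(C(=S)N/N=C3\C(=O)Nc4ccc(Cl)cc43)CC2)cc1` in this assay gives 7740 nM.
Compound 3 `O=C1Nc2ccc(Cl)cc2/C1=N/NC(=S)N1CCN(c2ccccc2F)CC1` in this assay gives 8290 nM.

Compound 3 has the highest number of the three, that is, the weakest inhibition; its gap to compound 2 is within the scatter, and only its gap to compound 1 is beyond it.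

Compound 4 `O=C1Nc2ccc(Cl)cc2/C1=N/NC(=S)N1CCN(c2ccc([N+](=O)[O-])cc2)CC1` is not yet measured. It differs from compound 3 in one place: 4-nitrophenyl in place of 2-fluorophenyl on an amine nitrogen in a ring.

Going by the values given here, two measured steps bear on this change, both replacing a hydrogen on the phenyl ring with a substituent: a 2.2-fold higher number from compound 1 to compound 2 (0.35 log units; beyond the scatter) and a 2.4-fold higher number from compound 1 to compound 3 (0.38 log units; beyond the scatter). Both made the number higher by a modest amount. The comparison of the two substituted compounds, a 1.1-fold higher number from compound 2 to compound 3 (0.03 log units; within the scatter), shows that which substituent is present, and where, made no difference beyond the scatter. Among the compounds with values here, the nitro group has no measured counterpart here, so the step from compound 3 to compound 4 is expected to be small, in either direction, and most likely within the scatter: a 1.0-fold lower number from compound 3 to compound 4 (0.02 log units; within the scatter). Compound 4 is therefore estimated at 8000 nM, with a range from 3500 nM to 18000 nM.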

Compound 4, half-maximal inhibitory concentration: 12000 nM
Compound 4: middle estimate off by 1.5-fold (0.18 log units), on the low side; measured number inside the range.
By their numbers in this assay, from the lowest: compound 1; then compounds 2, 3 and 4 (each within the scatter of the next).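

With a 4-nitrophenyl group on the ring nitrogen, the result in this assay stays level with the other two substituted compounds, as a 1.4-fold higher number from compound 3 to compound 4 (0.16 log units; within the scatter) and a 1.6-fold higher number from compound 2 to compound 4 (0.19 log units; within the scatter) both show. At this position, therefore, 4-nitrophenyl, 4-methoxyphenyl and 2-fluorophenyl cannot be told apart, even though nitro is a third kind of substituent and differs in its atoms from both methoxy and fluoro. Against the plain phenyl of compound 1, which remains the strongest inhibitor of the four, there is a 3.4-fold higher number from compound 1 to compound 4 (0.54 log units; beyond the scatter), so all three substituted compounds now show a higher number than the unsubstituted one, with no compound here going against that pattern, and nothing measured here gives a reason for it.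

Each substituent appears at only one place on the phenyl ring, so the compounds shown cannot separate the effect of the group from the effect of its place, for instance by comparing 2-nitrophenyl with 4-nitrophenyl. On these data alone, it also remains open whether a group such as an amine or a carboxylic acid on this ring would stay with the substituted compounds or match the plain phenyl of compound 1.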